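The source may hold more compounds than are shown below. What is called first, only, known or untested is meant among the compounds shown, and "the series" means these compounds.

Compound 1 `CSc1nc(-c2ccco2)c(C#N)c(=O)n1C` gives 79 ug/mL in a functional assay, with a stated time of 10 min; on this read-out higher numbers stand for weaker inhibition and lower numbers for stronger inhibition.
Compound 2 `CCOC(=O)c1cnn(-c2nc(-c3ccc(Cl)cc3)c(C#N)c(=O)n2C)c1N` gives 94 ug/mL in this assay.
Compound 3 `COc1cccc(-c2nc(SC)n(C)c(=O)c2C#N)c1OC` gives 43 ug/mL in this assay.

Among these three, compound 2 shows the highest number, though its gap to compound 1 lies within the usual scatter, so the two cannot be ranked; only compound 3 lies lower by a gap beyond the scatter.

Compound 4 `CCOC(=O)c1cnn(-c2nc(-c3ccccc3O)c(C#N)c(=O)n2C)c1N` is not yet measured. It differs from compound 2 in one place: 2-hydroxyphenyl in place of 4-chlorophenyl on an aromatic carbon. Going by the values given here, no pair of measured compounds shows this same change, so there is no measured step to lean on. The step of a 1.1-fold lower number from compound 2 to compound 4 (0.04 log units; within the scatter) is expected to stay within the scatter, in no clear direction. Compound 4 is therefore estimated at about 85 ug/mL in this assay, with a range from 35 ug/mL to 200 ug/mL.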

Compound 4, half-maximal inhibitory concentration: 58 ug/mL
For compound 4 the middle estimate is 1.5-fold (0.17 log units) above the measured one; measured number inside the range.
By their numbers in this assay, from the lowest: compounds 3, 4, 1 and 2 (each within the scatter of the next, the first and the last beyond it).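

At this aromatic carbon, 2-hydroxyphenyl in place of 4-chlorophenyl gives a 1.6-fold lower number from compound 2 to compound 4 (0.21 log units; within the scatter) in this assay so compound 2 and compound 4 cannot be ranked. The position thus takes a phenyl group carrying a hydrogen-bond donor, with no change that stands clear of the scatter. No available evidence bears on this result.

Going by these compounds, this single step swaps both the substituent and its place on the phenyl group, so the effect of each alone stays open. Also open, on these data alone, is how an amine or a carboxylic acid on that phenyl group would read.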